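The compounds below may be only part of what the source reports. "The series", "measured", "known", "first", "only" and "open" are said of these compounds alone.

Measured compounds in a functional assay on CHO-K1 cells for antagonist activity at transient receptor potential cation channel subfamily V member 1 (Homo sapiens), read by FLIPR; on this read-out lower numbers stand for stronger inhibition and higher numbers for weaker inhibition:

compound 1, `Cc1ccc(Cl)cc1Nc1nc(C(F)(F)F)ccc1CNC(=O)C(C)c1ccc(NS(C)(=O)=O)c(F)c1`, 140 nM
compound 2, `CCCN(CCC)c1nc(C(F)(F)F)ccc1CNC(=O)C(C)c1ccc(NS(C)(=O)=O)c(F)c1`, 14.7 nM
compound 3, `CC(C(=O)NCc1ccc(C(F)(F)F)nc1N1CCC(C(F)(F)F)CC1)c1ccc(NS(C)(=O)=O)c(F)c1`, 31 nM

Compound 3 stands second highest of the three numbers in this assay. Its nearest neighbour is compound 2, with a 2.1-fold higher number from compound 2 to compound 3 (0.32 log units; beyond the scatter); its furthest is compound 1, with a 4.5-fold lower number from compound 1 to compound 3 (0.65 log units; beyond the scatter). The remaining measured step, a 9.5-fold lower number from compound 1 to compound 2 (0.98 log units; beyond the scatter), also replaces the whole amine on the aromatic carbon of the shared core, and all three steps are modest in size.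

Compound 4, `CC(=O)OC1CCN(c2nc(C(F)(F)F)ccc2CNC(=O)C(C)c2ccc(NS(C)(=O)=O)c(F)c2)CC1`, differs from compound 3 by acetoxy in place of trifluoromethyl on a saturated ring carbon. Going by the values given here, none of the measured steps touches a substituent on the piperidine ring: each swaps the entire group on the aromatic carbon, so no step bears directly on this change. The three measured steps do show that changes at this region of the core move the number only modestly, which gives no reason to expect a large step here, in either direction. Compound 4 is therefore expected to give about 50 nM, with a range from 15 nM to 160 nM. For compound 4 this amounts to an expected step of a 1.6-fold higher number from compound 3 to compound 4 (0.21 log units; within the scatter), which may well lie within the scatter.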

Compound 4, half-maximal inhibitory concentration: 139 nM
Compound 4: the middle estimate sits 2.8-fold (0.44 log units) below what was measured; the range from low to high includes it.
By their numbers in this assay, from the lowest: compound 2; then compound 3; then compounds 4 and 1 (each within the scatter of the next).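

In this assay, the substituent on this saturated ring carbon, three ring bonds from the ring nitrogen, can move the number on its own: acetoxy in place of trifluoromethyl gives a 4.5-fold higher number from compound 3 to compound 4 (0.65 log units; beyond the scatter), whereas every earlier step swapped the entire group on the aromatic carbon. Read as whole groups, 4-acetoxypiperidin-1-yl in place of dipropylamino gives a 9.5-fold higher number from compound 2 to compound 4 (0.98 log units; beyond the scatter), and in place of (5-chloro-2-methylphenyl)amino it gives a 1.0-fold lower number from compound 1 to compound 4 (0.00 log units; within the scatter), so the gain seen with 4-(trifluoromethyl)piperidin-1-yl over that same group, a 4.5-fold lower number from compound 1 to compound 3 (0.65 log units; beyond the scatter), does not appear with acetoxy on the ring. Nothing shown here accounts for the difference between trifluoromethyl and acetoxy at this carbon.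

As far as these compounds go, it remains open how a hydroxy, methoxy or acetamido group on this ring carbon would compare with trifluoromethyl and acetoxy, and where a piperidin-1-yl group with no substituent at all would stand. With only one pair at this carbon, the compounds shown also cannot say whether a plain methyl or a larger ester such as benzoyloxy would follow trifluoromethyl or acetoxy.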